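Adding a third methoxy to a sulfonamide pyrazoline

The compounds below may be only part of what the source reports. "The series", "measured", "known", "first", "only" and "open" are said of these compounds alone.

Measured compounds in a functional assay on the whole organism for inhibition, with Rattus norvegicus as the target, read by paw edema, with a stated time of 3 h, at a dose of 50 mg/kg by the oral route; on this read-out higher numbers stand for more inhibition at the one dose given (going by the name of the read-out) and lower numbers for less inhibition:
compound 1 `CS(=O)(=O)c1ccc(C2=NN(c3ccc(S(N)(=O)=O)cc3)C(c3ccccc3)C2)cc1` gives 54.3%
compound 2 `COc1ccc(C2CC(c3ccc(S(C)(=O)=O)cc3)=NN2c2ccc(S(N)(=O)=O)cc2)cc1OC` gives 45.5%

Compound 2 holds the lower of the two numbers in this assay, with compound 1 nearest, yet the step of a number 8.8 percentage points lower from compound 1 to compound 2 (within the scatter) lies within the scatter, so the two cannot be ranked. Compound 3 `COc1cc(C2CC(c3ccc(S(C)(=O)=O)cc3)=NN2c2ccc(S(N)(=O)=O)cc2)cc(OC)c1OC` differs from compound 2 by methoxy in place of hydrogen on an aromatic carbon, the entering methoxy sitting ortho to a methoxy group. Among the compounds with values here, the only measured step, a number 8.8 percentage points lower from compound 1 to compound 2 (within the scatter), put 3,4-dimethoxyphenyl in place of phenyl and stayed within the scatter; a further methoxy is therefore expected to bring no step beyond the scatter, and the expected step is a number 0.5 percentage points lower from compound 2 to compound 3 (within the scatter). Compound 3 is estimated at 45%, between 30% and 60%.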

Compound 3, a percentage reported as inhibition, in the whole organism at one dose (the size of the read-out at that dose, not a potency): 73.7%
The estimate for compound 3 lay 28.7 percentage points below the measured number; the whole stated range lies below it.
By their numbers in this assay, from the lowest: compounds 2 and 1 (each within the scatter of the next); then compound 3.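

In this assay the methoxy entering ortho to a methoxy group gives a number 28.2 percentage points higher from compound 2 to compound 3 (beyond the scatter) and so shows that this ring position can respond to a change of this size. The 3,4,5-trimethoxyphenyl group also separates from phenyl, with a number 19.4 percentage points higher from compound 1 to compound 3 (beyond the scatter) as the step, which the 3,4-dimethoxyphenyl group did not do. Nothing available explains this rise.

As far as these compounds go, whether the response needs methoxy itself remains open, since ethoxy or a hydroxyl group at the same place could behave differently. From the compounds shown here alone, it is also open whether 3,5-dimethoxyphenyl would give a similar number.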